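The source may hold more compounds than are shown below. What is called first, only, known or untested is meant among the compounds shown, and "the series" means these compounds.

Of the compounds shown here, three on a shared core have been tested in a functional assay on MCF7 cells (Homo sapiens) for inhibition, read by sulforhodamine B assay (a lower number here means a stronger inhibitor, a higher number a weaker inhibitor), and none of them gives a number. Compound 2 `O=C1C=C(NC2CCCCC2)C(=O)c2c1nc1n2[C@H]2OC[C@@H](O)[C@H]2OC1`, with a cyclohexyl on an amine nitrogen, stands at > 8000 nM, which is a limit of the assay. Compound 3 `O=C1C(N2CCCCC2)=CC(=O)c2c1nc1n2[C@H]2OC[C@@H](O)[C@H]2OC1` gives > 8000 nM, also a limit. Compound 1 `Cc1ccc(NC2=CC(=O)c3c(nc4n3[C@H]3OC[C@@H](O)[C@H]3OC4)C2=O)cc1` gives > 4000 nM, which is likewise a limit. Compound 2 therefore has no number against which a change could be read, and the same holds for its two neighbours.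

Compound 4 `CCOc1ccc(NC2=CC(=O)c3nc4n(c3C2=O)[C@H]2OC[C@@H](O)[C@H]2OC4)cc1` follows from compound 2 by one change, 4-ethoxyphenyl in place of cyclohexyl on an amine nitrogen. Going by the values given here, the only measured step in the set is a step that the two limits leave unreadable from compound 1 to compound 3, so it offers no size to carry over. Compound 1 also carries an aromatic ring on an amine nitrogen, and its > 4000 nM is a limit too. No step beyond the scatter is therefore expected in this assay, in either direction, and a further limit would be no surprise. The expected step is an at least 1.3-fold lower number from compound 2 to compound 4 (0.12 log units; that floor lies within the scatter). For compound 4 the estimate is 6000 nM, with an expected range from 2000 nM to 16000 nM.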

Compound 4, half-maximal inhibitory concentration: 1430 nM
Compound 4: the middle estimate sits 4.2-fold (0.62 log units) above what was measured; measured number below the stated range.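

In this assay, going by these compounds alone, compound 4 is the first on the shared core to give a number rather than a limit, which shows that the group on this amine nitrogen, whose other neighbour is a double-bonded ring carbon, can move the read-out into the measurable range. Within the data shown here, putting 4-ethoxyphenyl in place of cyclohexyl gives an at least 5.5-fold lower number from compound 2 to compound 4 (0.74 log units; beyond the scatter), the first step in the set with a readable lower bound, since the earlier steps cannot be read. Its true size stays unknown because compound 2 sits at a limit rather than at a number: the limit of > 8000 nM in this assay, at which 2 of the 4 values shown sit.

Compound 1, which carries 4-methylphenyl on the same kind of amine nitrogen, stands at > 4000 nM, and this too is a limit, so an aromatic ring on that nitrogen does not by itself bring a compound on this core to a measured number. Going by these compounds, what remains open is how much of the change rests on the ethoxy group itself, and whether a 4-methoxyphenyl, a 4-chlorophenyl or a longer chain such as 4-butoxyphenyl on the same nitrogen would also give a number.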